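Swapping the sulfonamide on the shared core of compound 1

This account rests on a few compounds, and the source may have more. Where it says the series, first, only, none or still open, it means among the compounds named here.

Compound 1, with the structure `CCS(=O)(=O)Nc1cccc2c1CCCC2c1c[nH]cn1`, is one of three compounds tested in an assay on isolated protein for binding affinity to Alpha-2B adrenergic receptor (Rattus norvegicus), read by radioligand binding; on this read-out lower numbers stand for stronger inhibition and higher numbers for weaker inhibition. Compound 1 gives 1700 nM, the highest number of the three. Compound 2, `CCS(=O)(=O)Nc1cccc2c1CCC2c1c[nH]cn1`, gives 186 nM in this assay, and compound 3, `CS(=O)(=O)Nc1c(O)ccc2c1CCCC2c1c[nH]cn1`, gives 47.9 nM, so compound 1 binds more weakly than either, and both gaps lie beyond the usual scatter. These two compounds differ from compound 1 in more than one place, so no single-step comparison can be drawn from them.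

Compound 4, `O=C(Nc1cccc2c1CCCC2c1c[nH]cn1)C(F)(F)F`, has not yet been measured. It differs from compound 1 in one place: (trifluoromethyl)carbonyl in place of ethylsulfonyl on a nitrogen on an aromatic ring. Cut one bond further out, the change reads (ethylsulfonyl)amino to ((trifluoromethyl)carbonyl)amino. Within the data shown here, no measured pair shows what this swap does, so the size of the step is open. For compound 4 the expected step in this assay is a 1.5-fold higher number from compound 1 to compound 4 (0.17 log units; within the scatter), a shift no larger than the usual scatter, leaning toward weaker binding. Compound 4 is therefore estimated at 2500 nM, with a range from 600 nM to 9000 nM.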

Compound 4, inhibition constant: 661 nM
The estimate for compound 4 lay 3.8-fold (0.58 log units) above the measured number, within the range that was stated.
By their numbers in this assay, from the lowest: compound 3; then compound 2; then compound 4; then compound 1.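

In this assay, putting (trifluoromethyl)carbonyl in place of ethylsulfonyl on the nitrogen gives a 2.6-fold lower number from compound 1 to compound 4 (0.41 log units; beyond the scatter), a modest gain in binding. Among these compounds, this is the first one-place comparison in the set, and it shows that, on the core of compound 1, this nitrogen does not need the ethylsulfonyl group to keep its binding. The swap also changes several things at once, including the sulfur-containing group for a carbonyl, and ethyl for trifluoromethyl, and no measured property of either group accounts for the step. The compounds shown leave open whether the gain follows the carbonyl or the trifluoromethyl, which a plain acetyl group or a (trifluoromethyl)sulfonyl group on the same nitrogen could help separate. They also leave open whether the same swap would give a similar step on the cores of compound 2 and compound 3.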